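The source may report more compounds than this note shows. Statements on the series, on what has been measured and on what is new or still open speak of the compounds shown alone.

In a functional assay on MCF7 cells (Homo sapiens) for cytotoxicity, read by MTT assay, with a stated time of 72 h (on this read-out lower numbers stand for stronger inhibition and higher numbers for weaker inhibition), two compounds sharing one core have been measured so far. Compound 1 `CCCCc1ccc(NC(=O)CSC(=S)N[C@H]2CCOC2=O)cc1` gives 40200 nM. Compound 2 `O=C(CSC(=S)N[C@H]1CCOC1=O)Nc1ccc(C(=O)/C=C/c2ccccc2)cc1` gives 44300 nM, so it stands level with compound 1, the two values lying within the scatter of each other. Compound 3 `O=C(CSC(=S)N[C@H]1CCOC1=O)Nc1ccc(C(=O)/C=C/c2ccc([N+](=O)[O-])cc2)cc1` keeps everything in compound 2 except that 2-phenylethenyl becomes 2-(4-nitrophenyl)ethenyl, with nitro in place of hydrogen on an aromatic carbon. Within the data shown here, only one measured step bears on this, namely a 1.1-fold higher number from compound 1 to compound 2 (0.04 log units; within the scatter), which came with (2-phenylethenyl)carbonyl in place of butyl on an aromatic carbon. Among the measured compounds shown here, no measured compound carries a nitro, so the guidance is indirect. Resting on that single small step, no clear shift in either direction is expected, and the estimated change is a 1.2-fold lower number from compound 2 to compound 3 (0.07 log units; within the scatter), which stays within the scatter. Compound 3 is therefore estimated at 38000 nM, with an expected range of 15000 nM to 90000 nM.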

Compound 3, half-maximal inhibitory concentration: 2670 nM
Estimate against measurement, compound 3: 14-fold (1.15 log units) above; measured number outside the range, below it.
By their numbers in this assay, from the lowest: compound 3; then compounds 1 and 2 (each within the scatter of the next).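

In this assay, the ring carbon para to a large group proves highly sensitive: nitro in place of hydrogen there gives a 17-fold lower number from compound 2 to compound 3 (1.22 log units; beyond the scatter), a large step beyond the scatter. The earlier pair could not reveal this, since swapping butyl for (2-phenylethenyl)carbonyl, a far bigger change in structure, gave only a 1.1-fold higher number from compound 1 to compound 2 (0.04 log units; within the scatter), which lies within the scatter; here, adding just 3 heavy atoms changes the result far more. No measurement at hand explains why this step is so large.

Going by these compounds, it remains open whether this gain is specific to nitro or would also appear with another group at the same place, such as an amine, a methoxy group or a chlorine atom. The compounds shown also cannot tell how nitro would read elsewhere on this ring.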